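Sulfonamide to Benzamide on a Shared Core

A few compounds are considered here, and "the series" means these few. Any claim that something is new, unique, unknown or untested is made for them only; others in the source may bear on it.

Measured compounds:
compound 1 `CC(C)=CCC1Cc2c(OCCCNS(=O)(=O)c3ccc(Cl)cc3)cc(=O)n(CCCO)c2CC1(C)C` gives 24.7%
compound 2 `CC(C)=CCC1Cc2c(OCCCNS(=O)(=O)c3ccc(Br)cc3)cc(=O)n(CCCO)c2CC1(C)C` gives 19.5%

In a functional assay on PANC-1 cells (Homo sapiens) for inhibition, read by MTT assay, with a stated time of 24 h, tested at 10 uM (on this read-out higher numbers stand for more inhibition at the one concentration tested (going by the name of the read-out) and lower numbers for less inhibition), compound 1 gives 24.7%, and compound 2 gives 19.5%. Going by the values given here, the single measured step, a number 5.2 percentage points lower from compound 1 to compound 2 (within the scatter), comes from bromo in place of chloro on an aromatic carbon. Because that step is a number 5.2 percentage points lower from compound 1 to compound 2 (within the scatter), compound 2 cannot be separated from compound 1 on these numbers: the two stand within the scatter of each other, and compound 2 is simply the second of two closely placed values.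

Compound 3 `COc1ccc(C(=O)NCCCOc2cc(=O)n(CCCO)c3c2CC(CC=C(C)C)C(C)(C)C3)cc1` is not yet measured. It differs from compound 2 by (4-methoxyphenyl)carbonyl in place of (4-bromophenyl)sulfonyl on an amine nitrogen. Among the compounds with values here, no measured step bears on this kind of change; the only step available exchanges one halogen for another and stays within the scatter, so it offers no guide to replacing the sulfonyl linkage by a carbonyl one and the bromine by a methoxy group.

With nothing to point in either direction, compound 3 is expected to give a number close to that of compound 2, with a wide range, and the expected step is a number 0.5 percentage points higher from compound 2 to compound 3 (within the scatter). The estimate for compound 3 in this assay is 20%, between 5% and 40%.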

Compound 3, a percentage reported as inhibition, at one concentration (the size of the read-out at that concentration, not a potency): 55.5%
Compound 3: the middle estimate sits 35.5 percentage points below what was measured; the measured number lies above the stated range.
By their numbers in this assay, from the lowest: compounds 2 and 1 (each within the scatter of the next); then compound 3.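

In this assay the amine nitrogen proves to be a place where the read-out can move well beyond the scatter: the exchange of the sulfonyl groups for (4-methoxyphenyl)carbonyl gives a number 36 percentage points higher from compound 2 to compound 3 (beyond the scatter) and a number 30.8 percentage points higher from compound 1 to compound 3 (beyond the scatter) whereas the exchange of bromo for chloro on the aromatic carbon had left the two sulfonamides within the scatter of each other. The gain appears against both the (4-bromophenyl)sulfonyl and the (4-chlorophenyl)sulfonyl groups, so compound 3 stands above compound 1 and compound 2 alike, and the choice of halogen on the sulfonyl side does not alter that picture. No measurement at hand accounts for the size of these steps.

The change replaces the linkage and the ring substituent at once, so the compounds shown do not tell whether the carbonyl or the methoxy group carries the gain, a question that (4-methoxyphenyl)sulfonyl and (4-bromophenyl)carbonyl on the same amine nitrogen would separate. Also open, as far as these compounds go, is how the read-out would respond to a simple acetyl group or a longer chain between the carbonyl and the aromatic ring.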